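The source may hold more compounds than are shown below. What is called first, only, known or untested is meant among the compounds shown, and "the series" means these compounds.

Three close relatives of one shared core have been tested in a functional assay on U2OS cells (Homo sapiens) for antiproliferative activity, read by MTT assay, with a stated time of 72 h; a lower number here means a stronger inhibitor, a higher number a weaker inhibitor. Compound 1 `O=C(C1=C(O)C(=O)N(CCCn2ccnc2)C1c1ccc(Br)cc1)c1ccccc1` carries a hydroxy group on a double-bonded ring carbon of the five-membered non-aromatic ring and was reported as "not active" (no number reported), with no number given. Compound 2 `CCOC1=C(C(=O)c2ccccc2)C(c2ccc(Br)cc2)N(CCCn2ccnc2)C1=O` carries ethoxy on that carbon and gives 21900 nM, the lowest of the two numbers at hand. Compound 3 `CCOc1ccc(NC2=C(C(=O)c3ccccc3)C(c3ccc(Br)cc3)N(CCCn3ccnc3)C2=O)cc1` carries (4-ethoxyphenyl)amino there and gives 26200 nM; the step of a 1.2-fold higher number from compound 2 to compound 3 (0.08 log units; within the scatter) lies within the scatter, so the two compounds are best read as equal. Compound 4 `O=C(C1=C(NCc2ccccc2)C(=O)N(CCCn2ccnc2)C1c1ccc(Br)cc1)c1ccccc1` has not yet been measured. It differs from compound 2 by benzylamino in place of ethoxy on a double-bonded ring carbon. Among the compounds with values here, the only measured step that bears on this change is a 1.2-fold higher number from compound 2 to compound 3 (0.08 log units; within the scatter), where a different amino substituent took the place of the same ethoxy on the same carbon and nothing beyond the scatter followed. Compound 4 is therefore expected to show no step beyond the scatter, a 1.1-fold higher number from compound 2 to compound 4 (0.04 log units; within the scatter). Compound 4 is estimated at 24000 nM, within 8000 nM to 75000 nM.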

Compound 4, half-maximal inhibitory concentration: 32500 nM
Compound 4: middle estimate off by 1.4-fold (0.13 log units), on the low side, and the stated range covers the measured number.
By their numbers in this assay, from the lowest: compounds 2, 3 and 4 (each within the scatter of the next).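

In this assay, benzylamino brings an aromatic ring and a hydrogen-bond donor that ethoxy lacks on this double-bonded ring carbon, yet the change gives a 1.5-fold higher number from compound 2 to compound 4 (0.17 log units; within the scatter) and so stays within the usual scatter. Swapping the group on the amine nitrogen gives a 1.2-fold higher number from compound 3 to compound 4 (0.09 log units; within the scatter) and also stays within the scatter, so benzyl and 4-ethoxyphenyl cannot be told apart here, and compounds 2, 3 and 4 read as equal. No supporting measurement is available to explain why these different groups read alike.

The compounds shown leave open whether any group at this carbon can move the number beyond the scatter. A plain methylamino group, a longer chain between the amine nitrogen and the phenyl ring, or a carboxylic acid on that ring would each test this.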